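This account rests on a few compounds, and the source may have more. Where it says the series, first, only, none or still open, it means among the compounds named here.

Measured so far:
compound 1 `Cc1cc(C)c(NC(=O)C(C)(C)CCCCc2ccccc2)c2c1CC(C)(C)O2` — 210 nM
compound 2 `Cc1cc(C)c(NC(=O)C(C)(C)CCCCCOc2ccccc2)c2c1CC(C)(C)O2` — 86 nM

In an assay for inhibition of acyl-CoA:cholesterol acyltransferase (Oryctolagus cuniculus), using microsomes (on this read-out lower numbers stand for stronger inhibition and higher numbers for weaker inhibition), compound 2 stands lowest of the two numbers; compound 1 lies a 2.4-fold lower number from compound 1 to compound 2 (0.39 log units; beyond the scatter) away, a shift that comes from putting phenoxymethyl in place of phenyl. Compound 3 `Cc1cc(C)c(NC(=O)C(C)(C)CCCCCCOc2ccc(Cl)cc2)c2c1CC(C)(C)O2` is not yet measured; it carries (4-chlorophenoxy)methyl in place of phenoxy on a saturated chain carbon, six bonds along the chain from a carbonyl carbon. Within the data shown here, no measured step covers the chlorine, and only the single step from compound 1 to compound 2 speaks to lengthening the chain, which gave a modest gain. A further modest step in the same direction, or none beyond the scatter, is therefore expected. Compound 3 is estimated at 60 nM in this assay, between 25 nM and 150 nM, meaning a step of a 1.4-fold lower number from compound 2 to compound 3 (0.16 log units; within the scatter).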

Compound 3, half-maximal inhibitory concentration: 76 nM
Estimate against measurement, compound 3: 1.3-fold (0.10 log units) below; low and high end bracket the measured number.
By their numbers in this assay, from the lowest: compounds 3 and 2 (each within the scatter of the next); then compound 1.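

In this assay, (4-chlorophenoxy)methyl in place of phenoxy, six bonds along the chain from a carbonyl carbon, gives a 1.1-fold lower number from compound 2 to compound 3 (0.05 log units; within the scatter), so the extra chain carbon and the chlorine together bring no step beyond the scatter. The advantage over the phenyl chain remains, with a 2.8-fold lower number from compound 1 to compound 3 (0.44 log units; beyond the scatter). Nothing measured here explains either step.

The two changes arrive together, so the share of the chlorine and that of the extra chain carbon cannot be told apart. On these data alone, whether fluorine or methoxy in place of the chlorine, or a longer chain, would go further stays open.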